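The compounds below may be only part of what the source reports. "The series", "measured", "known", "first", "only" and "open" are said of these compounds alone.

Among the measured compounds shown here, compound 1 `CCCOc1cc2c(c3c1C[C@@H]1[C@@H](C)CO[C@]1(C)O3)C[C@@H]1[C@@H](C)CO[C@]1(C)O2` in a functional assay on aorta (Rattus norvegicus, strain Sprague-Dawley) for inhibition (a lower number here means that less compound is needed, a higher number that more compound is needed for the effect), gives 43000 nM and stands highest of the two numbers so far, with compound 2 `Cc1cc2c(c3c1C[C@@H]1[C@@H](C)CO[C@]1(C)O3)C[C@@H]1[C@@H](C)CO[C@]1(C)O2` nearest: compound 2 gives 40000 nM, and the step of a 1.1-fold lower number from compound 1 to compound 2 (0.03 log units; within the scatter) lies within the scatter. Compound 3 `CCCCCCOc1cc2c(c3c1C[C@@H]1[C@@H](C)CO[C@]1(C)O3)C[C@@H]1[C@@H](C)CO[C@]1(C)O2` reaches only a limit in this assay, at > 200000 nM. The two steps into compound 3, an at least 4.6-fold higher number from compound 1 to compound 3 (0.66 log units; beyond the scatter) and an at least 5.0-fold higher number from compound 2 to compound 3 (0.69 log units; beyond the scatter), are the only ones beyond the scatter, and both end at the limit (the limit of > 200000 nM in this assay, at which 1 of the 3 values shown sits).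

Compound 4 `C[C@H]1CO[C@]2(C)Oc3cc(OC/C=C/c4ccccc4)c4c(c3C[C@H]12)O[C@@]1(C)OC[C@H](C)[C@H]1C4` differs from compound 1 by 2-phenylethenyl in place of ethyl on a saturated chain carbon bound to an oxygen on an aromatic ring. The place is the same saturated chain carbon bound to an oxygen on an aromatic ring that is extended in the step to compound 3, so an at least 4.6-fold higher number from compound 1 to compound 3 (0.66 log units; beyond the scatter) is the step that bears most directly on it, and an at least 5.0-fold higher number from compound 2 to compound 3 (0.69 log units; beyond the scatter) points the same way. An at least modest move toward a higher number is therefore expected, a 2.8-fold higher number from compound 1 to compound 4 (0.45 log units; beyond the scatter), with a real chance that only a limit is returned. Compound 4 is estimated at 120000 nM, within a range of 40000 nM to 300000 nM, in this assay.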

Compound 4, half-maximal effective concentration: 64000 nM
Compound 4: the middle estimate sits 1.9-fold (0.27 log units) above what was measured; low and high end bracket the measured number.
By their numbers in this assay, from the lowest: compounds 2, 1 and 4 (each within the scatter of the next). At a limit, above all of these: compound 3.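

In this assay, 2-phenylethenyl with its six-membered aromatic ring is taken up at this saturated chain carbon bound to an oxygen on an aromatic ring with no step beyond the scatter, with a 1.5-fold higher number from compound 1 to compound 4 (0.17 log units; within the scatter) and a 1.6-fold higher number from compound 2 to compound 4 (0.20 log units; within the scatter). Extension at this place therefore does not always go with a move to a higher number, and with 2-phenylethenyl in place of pentyl the series shows an at least 3.1-fold lower number from compound 3 to compound 4 (0.49 log units; beyond the scatter). Compound 3 stands at a limit, so this last step gives a bound and not a size: the limit of > 200000 nM in this assay, at which 1 of the 4 values shown sits.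

The compounds shown leave open whether chain length alone sets the higher number of compound 3, or whether the double bond or the aromatic ring sets compound 4 apart from it. A butoxy chain, a saturated 3-phenylpropoxy chain, or an amine or a carboxylic acid at the chain end would bear on this.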